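From Pyrimidin-5-yl to 1-Methyl-1H-pyrazol-5-yl at a Limit

The compounds below may be only part of what the source reports. "The series", "measured", "known", "first", "only" and "open" are said of these compounds alone.

Compound 1, `CCN(c1ccc(C#N)c(Cl)c1)c1cc(-c2cncnc2)ccc1C`, gives > 30000 nM in a functional assay on PC-3 cells (Homo sapiens) for antiproliferative activity, read by CCK-8 assay, with a stated time of 6 days (on this read-out higher numbers stand for weaker inhibition and lower numbers for stronger inhibition), a limit of the assay. Compound 2, `CCN(c1cccc(-c2cncnc2)c1)c1ccc(C#N)c(Cl)c1`, gives > 30000 nM in this assay, also a limit. Compound 3, `N#Cc1ccc(N2CCc3cc(-c4ccncc4)ccc3C2)cc1C(F)(F)F`, gives "not determined" (no result reported) in this assay, so no result is reported for it.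

Compound 1 therefore stands only at a limit, and nothing places it among the other entries. Among the compounds with values here, the single one-place step, a step that the two limits leave unreadable from compound 1 to compound 2, is hydrogen in place of methyl on an aromatic carbon and cannot be read because of the limit of > 30000 nM in this assay, at which 2 of the 3 values shown sit.

Compound 4, `CCN(c1ccc(C#N)c(Cl)c1)c1cc(-c2ccnn2C)ccc1C`, differs from compound 1 by 1-methyl-1H-pyrazol-5-yl in place of pyrimidin-5-yl on an aromatic carbon. Within the data shown here, no measured step bears on this change, so no direction beyond the scatter is expected. Compound 4 is expected to give about 30000 nM (range 10000 nM to 100000 nM), a step of a number no higher from compound 1 to compound 4 (the limit leaves the size open), most likely reported again as a limit.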

Compound 4, half-maximal inhibitory concentration: 7290 nM
Beside the measured number, compound 4's estimate is 4.1-fold (0.61 log units) above it, and the stated range ends above it.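

In this assay, the group on this carbon, meta to a large group and para to a methyl group, does bear on the read-out: 1-methyl-1H-pyrazol-5-yl in place of pyrimidin-5-yl gives an at least 4.1-fold lower number from compound 1 to compound 4 (0.61 log units; beyond the scatter). The two groups have the same counts of heavy atoms and hydrogen-bond acceptors, so those counts alone do not set the result. The true size of the step stays open because compound 1 stands only at a limit: the limit of > 30000 nM in this assay, at which 2 of the 4 values shown sit.

The compounds shown leave open whether the methyl group on the pyrazole ring matters to this gain. They also do not show how an amine or a carboxylic acid at this position would read.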